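Swapping a piperidine for a piperazine in the microsome series

The compounds below may be only part of what the source reports. "The series", "measured", "known", "first", "only" and "open" are said of these compounds alone.

Compound 3 `c1ccc2c(c1)CN[C@@H](CN(CC[C@H]1CCCNC1)[C@H]1CCCc3cccnc31)C2` stands second highest of the three numbers measured in an ADME assay on microsomes from liver (Rattus norvegicus) for metabolic stability, read by LC-MS, with a stated time of 10 min, tested at 0.5 uM (a lower number here means that less of the compound is left, a higher number that more of the compound is left), giving 55%; compound 2 `c1ccc2c(c1)CN[C@@H](CN(CC1CCNCC1)[C@H]1CCCc3cccnc31)C2` gives 65%, within the scatter of it, while compound 1 `CN1CCN(CCCN(C[C@H]2Cc3ccccc3CN2)[C@H]2CCCc3cccnc32)CC1` gives 10%, the furthest away. Compound 4 `CC(C)N1CCN(CCCN(C[C@H]2Cc3ccccc3CN2)[C@H]2CCCc3cccnc32)CC1` differs from compound 3 in one place: (4-isopropylpiperazin-1-yl)methyl in place of piperidin-3-yl on a saturated chain carbon, two bonds along the chain from an amine nitrogen. The step that bears on this most is a number 45 percentage points higher from compound 1 to compound 3 (beyond the scatter), which runs the opposite way from the change now made; a number 55 percentage points higher from compound 1 to compound 2 (beyond the scatter) points the same way. A large fall in this assay is therefore expected, and the step of a number 40 percentage points lower from compound 3 to compound 4 (beyond the scatter) is estimated to be large. Compound 4 is expected to give 15%, with a range from 3% to 40%.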

Compound 4, percent of the compound remaining: 4%
Compound 4: the middle estimate sits 11 percentage points above what was measured, within the range that was stated.
By their numbers in this assay, from the lowest: compounds 4 and 1 (each within the scatter of the next); then compounds 3 and 2 (each within the scatter of the next).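

With isopropyl in place of methyl on an amine nitrogen in a ring, the number shifts only within the scatter (a number 6 percentage points lower from compound 1 to compound 4 (within the scatter)), so in this assay these two substituents cannot be told apart. The large falls (a number 51 percentage points lower from compound 3 to compound 4 (beyond the scatter)) and (a number 61 percentage points lower from compound 2 to compound 4 (beyond the scatter)) show that a low number is not confined to compound 1: it recurs with a second piperazine side chain, set against both piperidine compounds.

Going by these compounds, whether a piperazine with a free amine hydrogen, or a piperidine carrying isopropyl on its nitrogen, would fall with the low pair or the high pair remains open. Nothing measured here explains the gap between the piperazine and piperidine compounds.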